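Sulfonamide Oxadiazoles on Breast Cancer Cells: a Styryl Variant

A few compounds are considered here, and "the series" means these few. Any claim that something is new, unique, unknown or untested is made for them only; others in the source may bear on it.

Measured compounds:
compound 1 `NS(=O)(=O)c1cc(-c2nnc(CN3CCN(c4ccccc4)CC3)o2)c(Cl)cc1SCc1ccccc1`: 295000 nM
compound 2 `COc1ccc(-c2cn(Cc3nnc(-c4cc(S(N)(=O)=O)c(SCc5ccccc5)cc4Cl)o3)nn2)cc1`: 1500000 nM
compound 3 `NCc1nnc(-c2cc(S(N)(=O)=O)c(SCc3ccccc3)cc2Cl)o1`: 135000 nM

Of the compounds shown here, three sharing one core have been tested in a functional assay on MCF7 cells (Homo sapiens) for cytotoxicity, read by MTT assay, with a stated time of 72 h; a lower number here means a stronger inhibitor, a higher number a weaker inhibitor. Compound 3 stands lowest of the three numbers; its nearest neighbour is compound 1, and compound 2 lies furthest away. Within the data shown here, the only single-point step among them is a 2.2-fold lower number from compound 1 to compound 3 (0.34 log units; beyond the scatter), which runs from the larger phenylpiperazinylmethyl group to the small aminomethyl group and counts as modest. Among the measured compounds shown here, compound 2, which carries a larger substituted triazolylmethyl group, gives a number far higher than compound 3, though no single-point step connects the two.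

The unmeasured compound 4 `NS(=O)(=O)c1cc(-c2nnc(/C=C/c3ccc(Cl)cc3)o2)c(Cl)cc1SCc1ccccc1` differs from compound 3 by 2-(4-chlorophenyl)ethenyl in place of aminomethyl on an aromatic carbon. Both measured neighbours with a larger group in that place give higher numbers than compound 3, so the step from compound 1 to compound 3 is the one that bears on this change, and only loosely, since neither measured group resembles the styryl group. On that basis compound 4 is expected to show a number somewhat above compound 3 in this assay, with an estimated step of a 1.9-fold higher number from compound 3 to compound 4 (0.27 log units; within the scatter). The estimated value for compound 4 is 250000 nM, within a range from 60000 nM to 1000000 nM.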

Compound 4, half-maximal inhibitory concentration: 11000 nM
Estimate against measurement, compound 4: 23-fold (1.36 log units) above, and the stated range ends above it.
By their numbers in this assay, from the lowest: compound 4; then compound 3; then compound 1; then compound 2.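

In this assay the replacement of aminomethyl by 2-(4-chlorophenyl)ethenyl gives a 12-fold lower number from compound 3 to compound 4 (1.09 log units; beyond the scatter) and is a large step, so a group much bigger than aminomethyl on this aromatic carbon of the five-membered ring can go with a far lower number. Among the earlier compounds, the only single-point step ran the other way with respect to size, giving a 2.2-fold lower number from compound 1 to compound 3 (0.34 log units; beyond the scatter) as the larger 4-phenylpiperazin-1-yl gave way to amino, and compound 4 goes against any reading of that step as a rule that smaller is better at this place; size alone therefore does not set the direction here, and what enters matters more than how much enters. No measurement shown accounts for this drop.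

The compounds shown leave open which part of the entering group carries the change, the double bond outside the aromatic ring or the chlorine on it: a 2-phenylethenyl group without the chlorine and a saturated 2-(4-chlorophenyl)ethyl chain in the same place would separate the two. Also open, from the compounds shown here alone, is whether a different atom at that ring carbon, such as fluorine or a methoxy group in place of chlorine, would keep the number this low.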